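Nitro on compound 2: expected step

The compounds below may be only part of what the source reports. "The series", "measured", "known", "first", "only" and "open" are said of these compounds alone.

Values in a functional assay on HCT-116 cells (Homo sapiens) for cytotoxicity, read by MTT assay, with a stated time of 48 h; on this read-out higher numbers stand for weaker inhibition of growth and lower numbers for stronger inhibition of growth:
compound 1 `Cn1c(C(F)(F)F)nc2cc(Cl)c(Cl)cc21`: 56000 nM
compound 2 `FC(F)(F)c1nc2cc(Cl)c(Cl)cc2n1Cc1ccccc1`: 8600 nM
compound 3 `O=[N+]([O-])c1cccc(Cn2c(C(F)(F)F)nc3cc(Cl)c(Cl)cc32)c1`: 22800 nM

Compound 2 has the lowest number of the three, the strongest growth inhibition so far. Compound 4 `O=[N+]([O-])c1ccc(Cn2c(C(F)(F)F)nc3cc(Cl)c(Cl)cc32)cc1` differs from it by one change: nitro in place of hydrogen on an aromatic carbon, para to a large group. Within the data shown here, the closest precedent is a 2.7-fold higher number from compound 2 to compound 3 (0.42 log units; beyond the scatter), a modest rise from the same kind of exchange at a different place. The earlier 6.5-fold lower number from compound 1 to compound 2 (0.81 log units; beyond the scatter) brought in the phenyl that carries the nitro here. Among the measured compounds shown here, no measurement yet shows nitro at the place it occupies in compound 4, so a modest rise in this assay is expected, with wide uncertainty. The estimated step is a 1.9-fold higher number from compound 2 to compound 4 (0.27 log units; within the scatter). For compound 4 the estimated value is 16000 nM, with an expected range of 6000 nM to 40000 nM.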

Compound 4, concentration for 50% growth inhibition: 81600 nM
For compound 4 the middle estimate is 5.1-fold (0.71 log units) below the measured one; the measured number lies above the stated range.
By their numbers in this assay, from the lowest: compound 2; then compound 3; then compounds 1 and 4 (each within the scatter of the next).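

In this assay the nitro para to a large group gives a 9.5-fold higher number from compound 2 to compound 4 (0.98 log units; beyond the scatter) and so a larger rise than the other nitro placement with a 2.7-fold higher number from compound 2 to compound 3 (0.42 log units; beyond the scatter) on the same phenyl. Where the nitro sits therefore changes the outcome, with compound 3 at 22800 nM and compound 4 at 81600 nM on an otherwise identical structure. Neither nitro placement lowers the number from compound 2.

From the compounds shown here alone, whether an amine or a carboxylic acid at this same place on the phenyl would also raise the number stays open. No measurement at hand bears on why the two nitro placements differ.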